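Nitro for fluoro on the anilide of compound 1

The source may hold more compounds than are shown below. What is called first, only, known or untested is meant among the compounds shown, and "the series" means these compounds.

compound 1 `O=C(CSc1nccn1-c1ccc(Cl)cc1)Nc1ccccc1F`: > 345000 nM
compound 2 `O=C(CSc1nccn1-c1cccc2ccccc12)Nc1ccccc1Br`: 30500 nM

In an ADME assay on MT4 cells (Homo sapiens) for cytotoxicity, read by MTT assay (on this read-out lower numbers stand for higher toxicity in this test and higher numbers for lower toxicity in this test), compound 1 gives > 345000 nM, a limit of the test rather than a number, as shown by the limit of > 345000 nM in this assay, at which 1 of the 2 values shown sits. Compound 2 gives 30500 nM in this assay. Compound 1 and compound 2 differ in more than one place, so their values are only set side by side. Compound 3 `O=C(CSc1nccn1-c1ccc(Cl)cc1)Nc1ccccc1[N+](=O)[O-]` is not yet measured; it carries nitro in place of fluoro on an aromatic carbon, nitro in place of fluoro on an aromatic carbon. Within the data shown here, no measured step guides this change, so nothing beyond the scatter is expected. Compound 3 is estimated at 200000 nM, between 50000 nM and 400000 nM. The expected step of an at least 1.7-fold lower number from compound 1 to compound 3 (0.23 log units; that floor lies within the scatter) is small.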

Compound 3, half-maximal cytotoxic concentration: > 321000 nM
Compound 3 gave a limit, no number; the forecaster's own chance of this, stated with the estimate: 50%; at least 1.6-fold (0.20 log units) between middle value and limit.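

Among these compounds, compound 1 and compound 3 each give only a limit, not a number, so no step between them can be read. The compounds shown leave open whether nitro in place of fluoro on an aromatic carbon changes the value at all.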